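A few compounds are considered here, and "the series" means these few. Any claim that something is new, unique, unknown or untested is made for them only; others in the source may bear on it.

Measured compounds:
compound 1 `CC(C)=CCC/C(C)=C/CC/C(C)=C/CC[C@@H]1[C@@]2(C)CC/C(=N\OCc3cn(-c4ccccc4)nn3)C(C)(C)[C@@H]2CC[C@@]1(C)O` — 7760 nM
compound 2 `CC(C)=CCC/C(C)=C/CC/C(C)=C/CC[C@@H]1[C@@]2(C)CC/C(=N\OCc3cn(-c4ccc(Cl)cc4)nn3)C(C)(C)[C@@H]2CC[C@@]1(C)O` — 14800 nM

Both numbers come from a functional assay on HeLa cells (Homo sapiens) for cytotoxicity, read by MTT assay, with a stated time of 48 h; a higher number here means a weaker inhibitor, a lower number a stronger inhibitor. Compound 1 stands at the lower of the two numbers; compound 2 sits a 1.9-fold higher number from compound 1 to compound 2 (0.28 log units; within the scatter), so the two compounds cannot be ordered on these data.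

The next compound, compound 3 `CC(C)=CCC/C(C)=C/CC/C(C)=C/CC[C@@H]1[C@@]2(C)CC/C(=N\OCc3cn(-c4ccncc4)nn3)C(C)(C)[C@@H]2CC[C@@]1(C)O`, keeps the shared core and the oxime linker of compound 1 and differs only at the aromatic nitrogen of the five-membered ring: pyridin-4-yl in place of phenyl on an aromatic nitrogen.

Within the data shown here, the only step recorded so far touches the same aromatic ring, chloro in place of hydrogen, and reads a 1.9-fold higher number from compound 1 to compound 2 (0.28 log units; within the scatter). Among the measured compounds shown here, that is the sole guide, and it shows that a change on this ring left the number within the scatter. Going by these compounds, there is no measured case of a ring nitrogen entering this ring, so the direction of any effect is unknown. Compound 3 is therefore expected to land close to compound 1, as a 1.1-fold higher number from compound 1 to compound 3 (0.04 log units; within the scatter), without a step beyond the scatter. The estimate for compound 3 in this assay is 8500 nM, with a range from 3000 nM to 25000 nM.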

Compound 3, half-maximal inhibitory concentration: 18800 nM
Estimate against measurement, compound 3: 2.2-fold (0.34 log units) below, within the range that was stated.
By their numbers in this assay, from the lowest: compounds 1, 2 and 3 (each within the scatter of the next, the first and the last beyond it).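

In this assay, among these compounds, pyridin-4-yl in place of phenyl on the aromatic nitrogen gives the first step at this position that lies beyond the scatter, a 2.4-fold higher number from compound 1 to compound 3 (0.38 log units; beyond the scatter), whereas chloro in place of hydrogen on the phenyl ring stayed within it, a 1.9-fold higher number from compound 1 to compound 2 (0.28 log units; within the scatter). Pyridin-4-yl and 4-chlorophenyl cannot be told apart at this position, a 1.3-fold higher number from compound 2 to compound 3 (0.10 log units; within the scatter), so the only separation shown is the modest one between compound 1 and compound 3, with compound 2 within the scatter of both. Nothing at hand explains why the ring nitrogen in compound 3 is accompanied by this step.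

Open, going by these compounds, is whether this step depends on where the ring nitrogen sits, which pyridin-2-yl or pyridin-3-yl on the same aromatic nitrogen would test. Also open is how far this position tolerates other kinds of group, such as a benzyl group, a cyclohexyl ring, or a phenyl ring carrying an amine or a carboxylic acid, since the three compounds shown cover only a narrow range of aromatic rings.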